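The compounds below may be only part of what the source reports. "The series", "measured", "known", "first", "only" and "open" are said of these compounds alone.

Compound 1 `CC(C)C[C@@H](N)CN(C(=O)[C@@H]1C[C@H]1c1ccccc1)c1ccc(-c2ccccc2)cc1` gives 1.8 nM in a functional assay for agonist activity at G protein-coupled receptor 88 (Homo sapiens), read by HTRF and cAMP accumulation; a higher number here means that more compound is needed for the effect, a lower number that less compound is needed. For compound 2 `CC[C@H](C)[C@H](N)CN(C(=O)[C@@H]1C[C@H]1c1ccc(C#N)cc1)c1ccc(-c2ccccc2)cc1` this assay reports only a limit, > 25000 nM, so compound 2 sits at the limit of > 25000 nM in this assay, at which 1 of the 2 values shown sits. Compound 3 `CC[C@H](C)[C@H](N)CN(C(=O)[C@@H]1C[C@H]1c1nc(C)c(C)s1)c1ccc(-c2ccccc2)cc1` carries 4,5-dimethyl-1,3-thiazol-2-yl in place of 4-cyanophenyl on a saturated ring carbon. For the measured compounds named here, no measured pair shows this change, so the size of its step is unknown; since compound 2 stands at a limit, any movement beyond the scatter could only be towards less compound needed. The expected step is an at least 5.0-fold lower number from compound 2 to compound 3 (0.69 log units; beyond the scatter). Compound 3 is accordingly estimated at 5000 nM, with a range from 300 nM to 25000 nM.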

Compound 3, half-maximal effective concentration: 3600 nM
Estimate against measurement, compound 3: 1.4-fold (0.14 log units) above; measured number inside the range.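

In this assay the change from 4-cyanophenyl to 4,5-dimethyl-1,3-thiazol-2-yl on a saturated ring carbon gives an at least 6.9-fold lower number from compound 2 to compound 3 (0.84 log units; beyond the scatter) and so shows that this position of the three-membered ring responds to the group it carries. The true size of the step stays unknown, because compound 2 stands at a limit: the limit of > 25000 nM in this assay, at which 1 of the 3 values shown sits.

As far as these compounds go, whether the change comes from losing the nitrile or from replacing the ring itself stays open. So does what a plain phenyl, a pyridine ring or an unsubstituted thiazole would give on the core of compound 3.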